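Swapping an amine substituent on a curcumin-like chain

A few compounds are considered here, and "the series" means these few. Any claim that something is new, unique, unknown or untested is made for them only; others in the source may bear on it.

Measured so far:
compound 1, `COc1cc(/C=C/C(=O)/C=C(/C=C/c2ccc(OC(C)=O)c(OC)c2)NC2CCCCC2)ccc1OC(C)=O` — 113%
compound 2, `COc1cc(/C=C/C(=O)/C=C(/C=C/c2ccc(OC(C)=O)c(OC)c2)NCC(C)C)ccc1OC(C)=O` — 240%
compound 3, `COc1cc(/C=C/C(=O)/C=C(/C=C/c2ccc(O)c(OC)c2)NC2CCCCC2)ccc1O` — 191%

The read-out comes from a functional assay on EA.hy 926 cells (Homo sapiens), read by fluorescence, tested at 10 uM; a higher number here means a stronger effect of the compound at the concentration tested, a lower number a weaker effect. Compound 1 and compound 2 share one core and differ only in the group on the amine nitrogen: isobutyl in place of cyclohexyl on an amine nitrogen. This single swap gives a number 127 percentage points higher from compound 1 to compound 2 (beyond the scatter), a step well beyond the scatter. Compound 3 carries a different core; how the two cores differ is not broken down here. Compound 3 sits between the other two, its number lying beyond the scatter from both compound 1 and compound 2.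

Compound 4, `COc1cc(/C=C/C(=O)/C=C(/C=C/c2ccc(O)c(OC)c2)NCC(C)C)ccc1O`, has not yet been measured. It relates to compound 3 exactly as compound 2 relates to compound 1, the same change at the same place: isobutyl in place of cyclohexyl on an amine nitrogen. Because the earlier swap gave a number 127 percentage points higher from compound 1 to compound 2 (beyond the scatter), compound 4 is expected to show a large rise as well. The estimated step is a number 89 percentage points higher from compound 3 to compound 4 (beyond the scatter). For compound 4 the expected result is 280%, likely between 200% and 360%. The measurement will tell whether the earlier step carries over.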

Compound 4, a percentage reported as activity, at one concentration (the size of the read-out at that concentration, not a potency): 100%
Compound 4: middle estimate off by 180 percentage points, on the high side, and the stated range ends above it.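

In this assay, the same swap of isobutyl in place of cyclohexyl on the amine nitrogen gives a number 91 percentage points lower from compound 3 to compound 4 (beyond the scatter), so on this second core the change runs in the opposite direction. The effect of this swap therefore does not carry from one core to the other in this series, and the two steps are clearly different: the same change on two cores in this assay, a number 127 percentage points higher (beyond the scatter) from compound 1 to compound 2 and a number 91 percentage points lower (beyond the scatter) from compound 3 to compound 4, 218 percentage points apart, beyond the scatter of two such steps. This shows that the outcome of the swap depends on the core it sits on, but with only these two pairs it does not show which feature of the cores is responsible or why the direction flips, and each number is a read-out at one concentration, not a potency.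

Going by these compounds, it remains open how other groups on the amine nitrogen, such as a straight butyl chain, a cyclopentyl ring or a benzyl group, would behave on each core. On these data alone, it is also open whether either core would keep its direction of change with such groups.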